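A Lactam Ring Replaces a Dioxolane on the Shared Core

The source may report more compounds than this note shows. Statements on the series, on what has been measured and on what is new or still open speak of the compounds shown alone.

Within the data shown here, compound 2 `CCN(CC)c1ccc(NC(=O)c2c(-c3c(Cl)cccc3Cl)noc2CCC2OCCO2)cc1` is the compound with the lowest number so far in an in vitro assay on CHO-K cells with growth hormone secretagogue receptor type 1 (Homo sapiens) as the target; on this read-out higher numbers stand for weaker inhibition and lower numbers for stronger inhibition: in this assay compound 2 gives 25 nM. Among the measured compounds shown here, the only other measured compound is compound 1 `CCN(CC)c1ccc(NC(=O)c2c(-c3c(Cl)cccc3Cl)noc2C(C)C)cc1`, and in this assay compound 1 gives 150 nM. For the measured compounds named here, the one measured step, a 6.0-fold lower number from compound 1 to compound 2 (0.78 log units; beyond the scatter), shows that swapping a small branched group for a chain ending in a five-membered ring with two oxygens lowered the number, so a side chain of this kind is tolerated well on the shared core.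

Compound 3 `CCN(CC)c1ccc(NC(=O)c2c(-c3c(Cl)cccc3Cl)noc2CN2CCCC2=O)cc1` carries a different ring on that chain: 2-oxopyrrolidin-1-yl in place of (1,3-dioxolan-2-yl)methyl on a saturated chain carbon bound to an aromatic carbon. The replacement keeps the same heavy-atom count and a chain of similar reach, but the new ring holds a carbonyl in place of the two ether oxygens. Going by the values given here, no measured step bears directly on this swap, so the step of a 6.0-fold lower number from compound 1 to compound 2 (0.78 log units; beyond the scatter) serves only to say that a polar five-membered ring at this position is compatible with a low number.

Compound 3 is therefore expected to stay close to compound 2, with a slight loss allowed, an expected step of a 1.6-fold higher number from compound 2 to compound 3 (0.20 log units; within the scatter). The estimate for compound 3 in this assay is 40 nM, within a range from 10 nM to 160 nM.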

Compound 3, half-maximal inhibitory concentration: 122 nM
Estimate against measurement, compound 3: 3.1-fold (0.48 log units) below; low and high end bracket the measured number.
By their numbers in this assay, from the lowest: compound 2; then compounds 3 and 1 (each within the scatter of the next).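

The result shows that a good number at this position does not come with just any five-membered ring on the side chain. In this assay, 2-oxopyrrolidin-1-yl in place of (1,3-dioxolan-2-yl)methyl gives a 4.9-fold higher number from compound 2 to compound 3 (0.69 log units; beyond the scatter), although both groups hold the same number of heavy atoms and a five-membered non-aromatic ring. The gain over the isopropyl group does not carry over to the new ring, since a 1.2-fold lower number from compound 1 to compound 3 (0.09 log units; within the scatter) leaves the two compounds indistinguishable. The change alters several things at once: a ring nitrogen and a carbonyl replace the two ring oxygens, the acceptor count drops, and, read one bond further out, a 2-(1,3-dioxolan-2-yl)ethyl group gives way to a (2-oxopyrrolidin-1-yl)methyl group, and no measurement here explains the loss.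

The compounds shown leave open whether the loss follows the ring itself or its link to the core, a question that a 2-(2-oxopyrrolidin-1-yl)ethyl group could help to settle. They also leave open how an amine or a carboxylic acid at the end of a longer chain would fare at this position.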